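One Exchange, Made Twice, on Two Related Cores

A few compounds are considered here, and "the series" means these few. Any claim that something is new, unique, unknown or untested is made for them only; others in the source may bear on it.

Measured in an assay on isolated protein for inhibition of serine/threonine-protein kinase Chk2 (Homo sapiens), read by mobility shift assay, tested at 30 uM; on this read-out higher numbers stand for more inhibition at the one concentration tested (going by the name of the read-out) and lower numbers for less inhibition:
Compound 1 `Cc1cc2c(c(N)nn2C)c(N2CCCCC2)n1`: 4%
Compound 2 `COCCNc1nc(C)cc2c1c(N)nn2C`: -2%
Compound 3 `COCCNc1nc(C)cc2nn(-c3ccccc3)c(N)c12`: 4%

Among the measured compounds shown here, all three measured compounds sit at the low end of the read-out, and no pair of them is separated by more than the usual scatter. Compound 2 and compound 1 share a core and differ only by piperidin-1-yl in place of (2-methoxyethyl)amino on an aromatic carbon; this exchange gave a number 6 percentage points higher from compound 2 to compound 1 (within the scatter). Compound 3 carries a different core: the difference between the two cores is not broken down here, since compound 3 and compound 2 differ in more than one place. Compound 3 and compound 1 show no change at the digits reported.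

Compound 4 `Cc1cc2nn(-c3ccccc3)c(N)c2c(N2CCCCC2)n1` has not been measured in this assay. It arises from compound 3 by piperidin-1-yl in place of (2-methoxyethyl)amino on an aromatic carbon, the same change, at the same kind of place, that turned compound 2 into compound 1. Because compound 3 gives 4% and the earlier exchange moved the read-out by a number 6 percentage points higher from compound 2 to compound 1 (within the scatter), a step of about a number 2 percentage points higher from compound 3 to compound 4 (within the scatter) is expected here, well within the scatter. Compound 4 is therefore estimated at 6%, with a likely range from -6% to 18%.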

Compound 4, a percentage reported as inhibition, at one concentration (the size of the read-out at that concentration, not a potency): 4%
The estimate for compound 4 lay 2 percentage points above the measured number; measured number inside the range.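

In this assay, the exchange of (2-methoxyethyl)amino for piperidin-1-yl on the second core gave no change at the digits printed from compound 3 to compound 4 (within the scatter). Set beside the first case, the two steps do not differ by more than repeated measurements of this kind would allow: the same change on two cores in this assay, a number 6 percentage points higher (within the scatter) from compound 2 to compound 1 and no change at the digits printed (within the scatter) from compound 3 to compound 4, 6 percentage points apart, within the scatter of two such steps. This shows that, on these two cores, the change left the read-out at the low end both times, but it does not show that the change carries a definite effect from one core to the other, as neither step stands clear of the scatter and a shared effect cannot be told apart from no effect at all at the single concentration tested.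

The compounds shown leave open whether another group on this aromatic carbon, such as morpholin-4-yl, a primary amine or a longer chain ending in a carboxylic acid, would lift the read-out on either core. Going by these compounds, how the two cores themselves compare also stays open.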